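The source may hold more compounds than are shown below. What is called first, only, known or untested is meant among the compounds shown, and "the series" means these compounds.

Measured compounds:
Compound 1 `CC(C)Oc1ccccc1OC(C)C1=NCCN1` gives 0.7.
Compound 2 `Cc1cccc(C)c1OC(C)C1=NCCN1` gives 0.82.
Compound 3 `C=CCc1cccc(CC=C)c1OC(C)C1=NCCN1` gives 0.9.

All three numbers come from an assay on CHO cells with Alpha-2C adrenergic receptor (Homo sapiens) as the target; a higher number here means a larger maximal response, a lower number a smaller maximal response. Compound 1 stands lowest of the three. Its nearest neighbour is compound 2, whose number lies higher by more than the scatter; compound 3 lies further off, higher again by more than the scatter. Within the data shown here, no two measured compounds differ in one place only, so nothing measured so far shows how a single change moves the response.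

Compound 4 `COc1ccccc1OC(C)C1=NCCN1` has not been measured. It differs from compound 1 in one spot: methyl in place of isopropyl on an oxygen on an aromatic ring. The isopropyl group leaves and a methyl group enters on the oxygen on the aromatic ring. Compound 1 gives 0.7 and the two other measured compounds stay fairly close to it, so one expects only a small step in this assay, a number 0.050 higher from compound 1 to compound 4 (within the scatter), not beyond the scatter in either direction. Compound 4 is therefore estimated at 0.75, within a range from 0.6 to 0.9.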

Compound 4, intrinsic activity: the largest response reached, as a fraction of the reference agonist's: 0.6
Beside the measured number, compound 4's estimate is 0.15 above it, within the range that was stated.
By their numbers in this assay, from the lowest: compounds 4 and 1 (each within the scatter of the next); then compounds 2 and 3 (each within the scatter of the next).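

Among these compounds, this is the first comparison that differs in one place only. In this assay, methyl in place of isopropyl on an oxygen on an aromatic ring gives a number 0.10 lower from compound 1 to compound 4 (within the scatter), so going from isopropoxy to methoxy does not separate this pair beyond the usual scatter of the maximal response. That finding holds for these two compounds alone, and no available evidence bears on why the step is this size.

From the compounds shown here alone, it remains open whether a free hydroxyl, an ethoxy group or a longer chain such as butoxy at this place would move the response beyond the scatter. Compound 2 and compound 3 differ from compound 1 in more than one place, so their numbers cannot be tied to any single change on this oxygen.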